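A few compounds are considered here, and "the series" means these few. Any claim that something is new, unique, unknown or untested is made for them only; others in the source may bear on it.

Measured values in a functional assay on K562 cells (Homo sapiens) for inhibition, read by fluorescence, with a stated time of 72 h (a lower number here means a stronger inhibitor of growth, a higher number a weaker inhibitor of growth), are as follows
- Compound 1 `CCCCCCn1cnc2c(Nc3cc(OC)cc(OC)c3)nc(N[C@H]3CC[C@H](N)CC3)nc21` gives 1900 nM
- Compound 2 `CCCCCCn1cnc2c(Nc3ccc(O)cc3)nc(N[C@H]3CC[C@H](N)CC3)nc21` gives 5400 nM

Compound 2 holds the higher of the two numbers (5400 nM). Compound 3 `CCCCCCn1cnc2c(Nc3cccc(Cl)c3)nc(N[C@H]3CC[C@H](N)CC3)nc21` has 3-chlorophenyl in place of 4-hydroxyphenyl on a nitrogen on an aromatic ring and has not yet been measured. Among the measured compounds shown here, one measured step bears on this change (a 2.8-fold higher number from compound 1 to compound 2 (0.45 log units; beyond the scatter)), and it is modest. It swaps 3,5-dimethoxyphenyl for 4-hydroxyphenyl at the same place. A similarly modest move to a lower number is therefore expected in this assay (a 2.2-fold lower number from compound 2 to compound 3 (0.33 log units; beyond the scatter)). Compound 3 is estimated at 2500 nM (expected range 900 nM to 6500 nM).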

Compound 3, concentration for 50% growth inhibition: 2300 nM
Compound 3: middle estimate off by 1.1-fold (0.04 log units), on the high side; low and high end bracket the measured number.
By their numbers in this assay, from the lowest: compounds 1 and 3 (each within the scatter of the next); then compound 2.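

In this assay, 3-chlorophenyl in place of 4-hydroxyphenyl gives a 2.3-fold lower number from compound 2 to compound 3 (0.37 log units; beyond the scatter), while 3-chlorophenyl in place of 3,5-dimethoxyphenyl gives a 1.2-fold higher number from compound 1 to compound 3 (0.08 log units; within the scatter). At this position on the nitrogen, two different groups without a hydrogen-bond donor thus cannot be told apart, and among these three compounds only compound 2, with its 4-hydroxyphenyl, stands apart. No available evidence explains this difference. Still open, on these data alone, is whether 3-hydroxyphenyl or 4-chlorophenyl would separate the effect of the group from that of its location on the ring.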